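Lengthening the Bromoalkyl Tether: From Compound 1 to Compound 3

The source may report more compounds than this note shows. Statements on the series, on what has been measured and on what is new or still open speak of the compounds shown alone.

Measured in a functional assay on HCT-116 cells (Homo sapiens) for cytotoxicity, read by fluorescence and resazurin assay, with a stated time of 48 h; a higher number here means a weaker inhibitor, a lower number a stronger inhibitor:
- compound 1 `COc1ccc(/C=C/c2cc(/C=C/c3ccc(OC)cc3)nc(OCCCCBr)n2)cc1`: > 20000 nM
- compound 2 `BrCCCCCOc1nc(/C=C/c2ccccc2)cc(/C=C/c2ccccc2)n1`: > 20000 nM

In this assay compound 1 gives > 20000 nM, which is a limit of the assay and not a number. Compound 2 likewise returns only a limit, > 20000 nM. Everything known here thus sits at the limit of > 20000 nM in this assay, at which 2 of the 2 values shown sit. Compound 1 cannot be placed against anything else: both values shown are limits, so no ordering between them can be read.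

Compound 3 `COc1ccc(/C=C/c2cc(/C=C/c3ccc(OC)cc3)nc(OCCCCCCBr)n2)cc1` differs from compound 1 in one spot: 2-bromoethyl in place of bromo on a saturated chain carbon, four bonds along the chain from an oxygen on an aromatic ring. Among the compounds with values here, no step between measured compounds is known, so the direction of this change cannot be taken from the data. Because compound 1 gives only the limit > 20000 nM, the expectation is that compound 3 also stays beyond the reach of this assay, with an expected step that the limit leaves unreadable from compound 1 to compound 3, that is, nothing beyond the usual scatter. Compound 3 is therefore expected to come out near 35000 nM, within 15000 nM to 120000 nM.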

Compound 3, half-maximal inhibitory concentration: > 20000 nM
Compound 3 was reported as a limit (the forecaster's own chance of this, stated with the estimate: 85%); the middle value does not contradict the limit.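

No step can be read from compound 1 to compound 3, since both results are limits of the assay and not numbers: the limit of > 20000 nM in this assay, at which 3 of the 3 values shown sit. The compounds shown leave open which structural change, if any, would give a readable value in this assay.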